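From pyridin-4-yl to 4-nitrophenyl on a carbonyl carbon

This account rests on a few compounds, and the source may have more. Where it says the series, first, only, none or still open, it means among the compounds named here.

Of the compounds shown here, three have so far been tested in a functional assay on MDA-MB-231 cells (Homo sapiens) for antiproliferative activity, read by MTT assay, with a stated time of 72 h; on this read-out higher numbers stand for weaker inhibition and lower numbers for stronger inhibition. Compound 1 `CC1=CC[C@H]2[C@@H]1CC=C(C)[C@@H](CCC1=C(C)CC[C@@H]3OC(C)(C)[C@@H](O)CC[C@@]13C)C2(C)C` gives > 50000 nM, which is a limit of the assay and not a number. Compound 2 `CC1=CC[C@H]2[C@H](CC[C@]2(C)O)C(C)(C)[C@@H]1CC[C@H]1[C@]2(C)CC[C@H](OC(=O)c3ccncc3)C(C)(C)O[C@H]2CC[C@@]1(C)O` gives 18000 nM. Compound 3 `CC1=CC[C@H]2[C@@H]1CC=C(C)[C@@H](CC[C@H]1[C@]3(C)CC[C@H](OC(=O)c4ccccc4)C(C)(C)O[C@H]3CC[C@@]1(C)O)C2(C)C` gives 18400 nM. Compound 2 therefore has one numerical neighbour, and the two values lie within the scatter of each other.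

Compound 4 `CC1=CC[C@H]2[C@H](CC[C@]2(C)O)C(C)(C)[C@@H]1CC[C@H]1[C@]2(C)CC[C@H](OC(=O)c3ccc([N+](=O)[O-])cc3)C(C)(C)O[C@H]2CC[C@@]1(C)O` has 4-nitrophenyl in place of pyridin-4-yl on a carbonyl carbon. Among the measured compounds shown here, no measured pair isolates this change, so the expectation rests on thin evidence. Compound 3, whose ester ring is of carbon only, gives 18400 nM, although it also differs from compound 2 elsewhere in its structure. On that basis, no step beyond the scatter is expected in this assay, in either direction. The estimated step is no change at the digits printed from compound 2 to compound 4 (within the scatter). The estimate for compound 4 is 18000 nM, with an expected range from 7000 nM to 45000 nM.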

Compound 4, half-maximal inhibitory concentration: 8900 nM
Compound 4: middle estimate off by 2.0-fold (0.31 log units), on the high side; low and high end bracket the measured number.
By their numbers in this assay, from the lowest: compound 4; then compounds 2 and 3 (each within the scatter of the next). At a limit, above all of these: compound 1.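

In this assay, 4-nitrophenyl in place of pyridin-4-yl on a carbonyl carbon gives a 2.0-fold lower number from compound 2 to compound 4 (0.31 log units; beyond the scatter), and this is the only step shown that isolates a single change. Among the compounds shown here, it shows that the group on this carbonyl carbon can move the number beyond the scatter, which the earlier compounds could not show, as compound 2 and compound 3 differ elsewhere in their structures as well. Nothing shown here accounts for the step, which is modest and rests on one pair.

This one pair leaves open whether the step follows the nitro group or the ring of carbon only, and a plain phenyl on the core of compound 2 would separate the two. On these data alone, how a 4-aminophenyl or a 4-carboxyphenyl would read on this carbonyl carbon also stays open.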